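Fluoro in Place of Hydrogen: What Compound 4 Might Give

A few compounds are considered here, and "the series" means these few. Any claim that something is new, unique, unknown or untested is made for them only; others in the source may bear on it.

Three compounds have been measured in a functional assay on A549 cells (Homo sapiens) for antiproliferative activity, read by MTT assay, with a stated time of 72 h; a lower number here means a stronger inhibitor, a higher number a weaker inhibitor:
compound 1, `C=C(Cl)C(=O)Nc1cc(Nc2nc(C)cc(-c3cn(C)c4ccccc34)n2)c(OC)cc1N(C)CCN(C)C`, 1730 nM
compound 2, `COc1cc(N(C)CCN(C)C)c(NC(=O)/C=C\C(C)C)cc1Nc1nc(C)cc(-c2cn(C)c3ccccc23)n1`, 1070 nM
compound 3, `CCC/C=C\C(=O)Nc1cc(Nc2nc(C)cc(-c3cn(C)c4ccccc34)n2)c(OC)cc1N(C)CCN(C)C`, 329 nM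

Compound 2 holds the second highest of the three numbers; compound 1 is its nearest neighbour, with a 1.6-fold lower number from compound 1 to compound 2 (0.21 log units; within the scatter), and compound 3 lies furthest away, with a 3.3-fold lower number from compound 2 to compound 3 (0.51 log units; beyond the scatter). Compound 4, `COc1cc(N(C)CCN(C)C)c(NC(=O)/C=C\C(C)C)cc1Nc1nc(C)cc(-c2cn(C)c3ccc(F)cc23)n1`, differs from compound 2 by fluoro in place of hydrogen on an aromatic carbon, read one bond further out as 1-methyl-1H-indol-3-yl becoming 5-fluoro-1-methyl-1H-indol-3-yl. For the measured compounds named here, none of the measured steps touches that ring: a 1.6-fold lower number from compound 1 to compound 2 (0.21 log units; within the scatter), a 5.3-fold lower number from compound 1 to compound 3 (0.72 log units; beyond the scatter) and a 3.3-fold lower number from compound 2 to compound 3 (0.51 log units; beyond the scatter) all change the group on the carbonyl carbon. Going by the values given here, no measured step therefore bears directly on this change, and no step beyond the scatter is expected in this assay. Compound 4 is estimated at 1000 nM, between 400 nM and 2500 nM, which corresponds to an expected 1.1-fold lower number from compound 2 to compound 4 (0.03 log units; within the scatter).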

Compound 4, half-maximal inhibitory concentration: 9080 nM
Beside the measured number, compound 4's estimate is 9.1-fold (0.96 log units) below it; measured number above the stated range.
By their numbers in this assay, from the lowest: compound 3; then compounds 2 and 1 (each within the scatter of the next); then compound 4.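

Until now only the group on the carbonyl carbon had changed, and this result shows that the 1-methyl-1H-indol-3-yl group also counts in this assay: going to 5-fluoro-1-methyl-1H-indol-3-yl gives an 8.5-fold higher number from compound 2 to compound 4 (0.93 log units; beyond the scatter). The added fluoro therefore makes a weaker inhibitor, by a step beyond the scatter. Nothing available accounts for this loss. As far as these compounds go, whether a nitrile or an amine at this carbon would also weaken the inhibitor remains open. So does whether fluoro has the same effect with the pent-1-en-1-yl group of compound 3.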